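This account rests on a few compounds, and the source may have more. Where it says the series, first, only, none or still open, it means among the compounds named here.

Measured in an assay on isolated protein for inhibition of DNA topoisomerase 1 (Homo sapiens), with a stated time of 30 min, tested at 100 uM; a lower number here means a weaker effect, a higher number a stronger effect of the compound at the concentration tested:
- compound 1 `O=C(CN1CCN(c2cc3c(cc2F)c(=O)c(C(=O)O)cn3C2CC2)CC1)Nc1ccc(C(=O)/C=C/c2cccc(Cl)c2)cc1` — 68.8%
- compound 2 `O=C(CN1CCN(c2cc3c(cc2F)c(=O)c(C(=O)O)cn3C2CC2)CC1)Nc1ccc(C(=O)/C=C/c2ccc(Cl)cc2)cc1` — 67.5%
- compound 3 `COc1ccc(/C=C/C(=O)c2ccc(NC(=O)CN3CCN(c4cc5c(cc4F)c(=O)c(C(=O)O)cn5C4CC4)CC3)cc2)cc1OC` — 73.2%

On the numbers shown, compound 3 carries the top figure of the three, but that standing is nominal: a number 4.4 percentage points higher from compound 1 to compound 3 (within the scatter) and a number 5.7 percentage points higher from compound 2 to compound 3 (within the scatter) are both within the scatter, so the three compounds sit at one level in this assay. The remaining step, a number 1.3 percentage points lower from compound 1 to compound 2 (within the scatter), is also within the scatter. All three measured steps exchange the aryl group on the double-bonded chain carbon bound to a double-bonded chain carbon while the shared core of compound 1, the piperazine linker, the amide and the enone are held fixed, and none of them moved the read-out beyond the noise.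

The next compound, compound 4 `O=C(CN1CCN(c2cc3c(cc2F)c(=O)c(C(=O)O)cn3C2CC2)CC1)Nc1ccc(C(=O)/C=C/c2cccc([N+](=O)[O-])c2)cc1`, makes the same kind of exchange: 3-nitrophenyl in place of 3,4-dimethoxyphenyl on a double-bonded chain carbon bound to a double-bonded chain carbon. The three exchanges at this position that have been measured bear directly on it and were all flat, so the expectation is for no step beyond the scatter in this assay, a number 4.2 percentage points lower from compound 3 to compound 4 (within the scatter), with no clear direction. Compound 4 is therefore expected to give about 69% in this assay, within a range of 57% to 81%.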

Compound 4, a percentage reported as inhibition, at one concentration (the size of the read-out at that concentration, not a potency): 90.5%
The estimate for compound 4 lay 21.5 percentage points below the measured number, outside the stated range (above it).
By their numbers in this assay, from the lowest: compounds 2, 1 and 3 (each within the scatter of the next); then compound 4.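

In this assay, the aryl group on a double-bonded chain carbon bound to a double-bonded chain carbon can move the read-out beyond the scatter, which none of the earlier exchanges at this place did: a number 17.3 percentage points higher from compound 3 to compound 4 (beyond the scatter), and a number 23 percentage points higher from compound 2 to compound 4 (beyond the scatter). The closest comparison is the exchange of nitro for chloro on an aromatic carbon, a number 21.7 percentage points higher from compound 1 to compound 4 (beyond the scatter), so this single substituent change is enough to separate compound 4 from the level shared by the other three. No measurement at hand accounts for this step.

On these data alone, with one nitro compound, it remains open whether the higher read-out is particular to the nitro group or would also appear with a nitrile, an amine or a carboxylic acid in its place. As far as these compounds go, each figure also comes from a single concentration, so how far compound 4 stands apart in potency from the other three remains open as well.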